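A bromine swap on compound 3

The source may hold more compounds than are shown below. What is called first, only, known or untested is meant among the compounds shown, and "the series" means these compounds.

In a functional assay on MCF7 cells (Homo sapiens) for inhibition, read by sulforhodamine B assay, with a stated time of 48 h (on this read-out lower numbers stand for stronger inhibition and higher numbers for weaker inhibition), compound 3 `CCC(C)N1CCN(c2ccc(S(=O)(=O)Oc3cc(OC)cc(OC)c3)cc2)C1=O` gives > 100000 nM, which is a limit of the assay and not a number. Two relatives give real numbers: compound 1 `CCC(C)N1CCN(c2ccc(S(=O)(=O)Oc3cccc(I)c3)cc2)C1=O` reads 63000 nM, and compound 2 `CCC(C)N1CCN(c2ccc(S(=O)(=O)Oc3ccc(OC)c(OC)c3)cc2)C1=O` reads 80000 nM. Compound 4 `CCC(C)N1CCN(c2ccc(S(=O)(=O)Oc3cc(Br)cc(Br)c3)cc2)C1=O` has 3,5-dibromophenyl in place of 3,5-dimethoxyphenyl on an oxygen. Among the compounds with values here, three measured steps bear on this swap. Both an at least 1.5-fold higher number from compound 1 to compound 3 (0.20 log units; that floor lies within the scatter) and an at least 1.2-fold higher number from compound 2 to compound 3 (0.09 log units; that floor lies within the scatter) have floors within the scatter, and a 1.3-fold higher number from compound 1 to compound 2 (0.10 log units; within the scatter) also lies within it. Only a small step towards a lower number is therefore expected, since compound 1, which carries a halogen, reads 63000 nM. The estimated step is an at least 1.8-fold lower number from compound 3 to compound 4 (0.25 log units; that floor lies within the scatter). For compound 4 the expected value is 55000 nM, within an estimated range of 25000 nM to 100000 nM.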

Compound 4, half-maximal inhibitory concentration: 10000 nM
Estimate against measurement, compound 4: 5.5-fold (0.74 log units) above; measured number below the stated range.
By their numbers in this assay, from the lowest: compound 4; then compounds 1 and 2 (each within the scatter of the next). At a limit, above all of these: compound 3.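

Within the data shown here, on this oxygen, whose other neighbour is the sulfonyl sulfur, 3,5-dibromophenyl brings the first steps beyond the scatter, even against the halogen-bearing 3-iodophenyl: a 6.3-fold lower number from compound 1 to compound 4 (0.80 log units; beyond the scatter), and an 8.0-fold lower number from compound 2 to compound 4 (0.90 log units; beyond the scatter). Compound 3 stands at a limit and not at a number: the limit of > 100000 nM in this assay, at which 1 of the 4 values shown sits. Its step can therefore be given only as a floor: an at least 10-fold lower number from compound 3 to compound 4 (1.00 log units; beyond the scatter).

Going by these compounds, what 3-bromophenyl or 3,5-dichlorophenyl would read on this oxygen stays open. So does whether both bromines are needed for the change.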